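Cytotoxicity of Two Nitroimidazole Ether Series: A Fluorine Swap

The compounds below may be only part of what the source reports. "The series", "measured", "known", "first", "only" and "open" are said of these compounds alone.

Compound 1 `O=[N+]([O-])c1cn2c(n1)OC[C@@H](OCc1cccc(-c3ccc(C(F)(F)F)cc3)c1)C2` and compound 2 `O=[N+]([O-])c1cn2c(n1)OC[C@@H](OCc1cccc(-c3ccc(F)cc3)c1)C2` share one core, and compound 2 differs from compound 1 by fluoro in place of trifluoromethyl on an aromatic carbon. In an ADME assay on Vero cells (Chlorocebus sabaeus) for cytotoxicity, with a stated time of 72 h (a higher number here means a weaker inhibitor, a lower number a stronger inhibitor), compound 1 gives only a limit, > 128000 nM. Compound 2 likewise gives only a limit in this assay, namely > 128000 nM. The step that the two limits leave unreadable from compound 1 to compound 2 therefore cannot be sized. Compound 3 `O=[N+]([O-])c1cn2c(n1)OC[C@@H](OCc1ccn(-c3ccc(C(F)(F)F)cc3)n1)C2` rests on a second core; the difference between the two cores is not broken down here. In this assay compound 3 again gives only a limit, > 128000 nM. Compound 4 `O=[N+]([O-])c1cn2c(n1)OC[C@@H](OCc1ccn(-c3ccc(F)cc3)n1)C2` has not yet been measured and differs from compound 3 by fluoro in place of trifluoromethyl on an aromatic carbon, the same change as that from compound 1 to compound 2, at the same place. The expected step of a number no higher from compound 3 to compound 4 (the limit leaves the size open) rests on (the limit of > 128000 nM in this assay, at which 3 of the 3 values shown sit). Compound 4 is expected to give 128000 nM.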

Compound 4, half-maximal inhibitory concentration: > 128000 nM
Compound 4: a limit, no number; the forecaster's own chance of this, stated with the estimate: 90%; the middle value sits exactly at the limit.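

Compound 3 and compound 4 each give only a limit in this assay, so the size of the step between them cannot be read. The compounds shown leave open whether swapping trifluoromethyl for fluoro changes cytotoxicity on either core.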